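The compounds below may be only part of what the source reports. "The series", "measured", "known", "first", "only" and "open" are said of these compounds alone.

Compound 1 `CCOC(=O)c1ccc(-c2ccc(N(C)C)nn2)cc1` in a functional assay on Huh-7 cells (Homo sapiens) for antiproliferative activity, with a stated time of 48 h (on this read-out lower numbers stand for stronger inhibition and higher numbers for weaker inhibition), gives > 25000 nM
Compound 2 `COC(=O)c1ccc(-c2ccc(N(C)C)nn2)cc1` in this assay gives > 25000 nM

Compound 1 stands at > 25000 nM as a limit of the assay and not a number. Compound 2 stands at > 25000 nM as a limit too. The picture so far is the limit of > 25000 nM in this assay, at which 2 of the 2 values shown sit, and no actual number exists yet.

Compound 3 `CCOC(=O)c1ccc(-c2ccc(OC(C)C)nn2)cc1` differs from compound 1 in one place, with isopropoxy in place of dimethylamino on an aromatic carbon of a six-membered aromatic ring with 2 nitrogen. The counted difference is isopropoxy in place of dimethylamino on an aromatic carbon and the rest of the molecule stays the same.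

Within the data shown here, the only measured step is a step that the two limits leave unreadable from compound 1 to compound 2 and it lies on a saturated chain carbon rather than on that aromatic carbon, so it gives no size for this change. Compound 1 offers only > 25000 nM as a limit to start from, so no direction can be argued. The estimate therefore means a number no higher from compound 1 to compound 3 (the limit leaves the size open) as the expected step, with compound 3 staying close to that limit. For compound 3 the estimated value in this assay is 25000 nM with an expected range from 8000 nM to 50000 nM and a good chance that the outcome is expected to be only a limit.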

Compound 3, half-maximal inhibitory concentration: > 25000 nM
Compound 3: no number, only a limit (the forecaster's own chance of this, stated with the estimate: 70%); the middle value lies on the limit itself.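

No step can be read between compound 1 and compound 3, because both values are limits of the assay and not numbers: the limit of > 25000 nM in this assay, at which 3 of the 3 values shown sit.

The compounds shown leave open how strongly any of them acts in this assay and whether isopropoxy in place of dimethylamino changes that activity at all.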